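Quinazoline-linked anilides: from a urea to a benzylic amine

The source may report more compounds than this note shows. Statements on the series, on what has been measured and on what is new or still open speak of the compounds shown alone.

Measured compounds:
- compound 1, `COc1cc(Nc2ncnc3c(NC(=O)Nc4cc(F)cc(F)c4)cccc23)cc(OC)c1` — 2630 nM
- compound 2, `COc1cc(Nc2ncnc3c(NC(=O)Nc4cccc(C)c4C)cccc23)cc(OC)c1` — 5910 nM

Both compounds were tested in a functional assay on RT-112 cells (Homo sapiens) for antiproliferative activity, read by MTT assay, with a stated time of 72 h; on this read-out lower numbers stand for stronger inhibition of growth and higher numbers for weaker inhibition of growth. Compound 2 stands at the higher of the two numbers: the step of a 2.2-fold higher number from compound 1 to compound 2 (0.35 log units; beyond the scatter) places it beyond the scatter from compound 1, so of these two, compound 2 inhibits growth less strongly.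

Compound 3, `COc1cc(Nc2ncnc3c(NC(=O)c4ccc(CN(C)C)cc4)cccc23)cc(OC)c1`, has not been measured. It differs from compound 2 in one place: 4-((dimethylamino)methyl)phenyl in place of (2,3-dimethylphenyl)amino on a carbonyl carbon. For the measured compounds named here, this change alters the group attached to the carbonyl carbon rather than the aryl ring borne on the amide-type nitrogen, so the single measured step, a 2.2-fold higher number from compound 1 to compound 2 (0.35 log units; beyond the scatter), bears only loosely on it; that step swapped one aryl substituent for another while keeping the (2,3-dimethylphenyl)amino-type arrangement, and it was modest. Going by the values given here, no measured pair shows the effect of replacing the (2,3-dimethylphenyl)amino group itself. On that basis, no firm direction can be expected, and the step of a 1.5-fold lower number from compound 2 to compound 3 (0.17 log units; within the scatter) is an estimate carrying wide uncertainty. Compound 3 is therefore expected to give about 4000 nM in this assay, within a range of 800 nM to 20000 nM.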

Compound 3, concentration for 50% growth inhibition: 4370 nM
For compound 3 the middle estimate is 1.1-fold (0.04 log units) below the measured one; measured number inside the range.
By their numbers in this assay, from the lowest: compounds 1, 3 and 2 (each within the scatter of the next, the first and the last beyond it).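

In this assay, the earlier pair changed only the aryl ring on the urea, whereas compound 3 replaces the whole arylamino group on the carbonyl carbon with 4-((dimethylamino)methyl)phenyl, turning the urea into an amide. The step of a 1.4-fold lower number from compound 2 to compound 3 (0.13 log units; within the scatter) and the step of a 1.7-fold higher number from compound 1 to compound 3 (0.22 log units; within the scatter) both lie within the scatter, so at this place the urea nitrogen and its hydrogen-bond donor can be exchanged for a benzylic amine without the number separating from that of either urea, even though compound 1 and compound 2 lie beyond the scatter of each other. Nothing given here accounts for why the numbers stay this close.

The compounds shown do not separate the contribution of the dimethylamino group from that of the amide change, and a plain phenyl ring on the carbonyl carbon, or a morpholine or a primary amine in place of the dimethylamino group, would address that. They also leave open whether a carboxylic acid on the same benzylic carbon, or a longer chain between the ring and the amine, would move the number beyond the scatter.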